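The compounds below may be only part of what the source reports. "The series", "measured", "known", "first", "only" and "open" are said of these compounds alone.

Three compounds have been measured in a functional assay on K562 cells (Homo sapiens) for antiproliferative activity, read by MTT assay, with a stated time of 5 days; on this read-out lower numbers stand for stronger inhibition and higher numbers for weaker inhibition:

Compound 1 `COc1ccc(/C=C(/C(=O)c2cc(OC)c(OC)c(OC)c2)c2ccccc2O)cc1O` gives 49000 nM.
Compound 2 `COc1ccc(/C=C(/C(=O)c2cc(OC)c(OC)c(OC)c2)c2ccccc2O)cc1F` gives 60000 nM.
Compound 3 `COc1ccc(C=C(C(=O)c2cc(OC)c(OC)c(OC)c2)c2ccc(C)cc2)cc1F` gives 570000 nM.

Compound 1 and compound 2 share a core and differ in one place: hydroxy in place of fluoro on an aromatic carbon. This exchange gave a 1.2-fold lower number from compound 2 to compound 1 (0.09 log units; within the scatter), so on this read-out the two compounds cannot be told apart. Compound 3 carries a different core; how its core differs from that of compound 2 is not broken down here, but its number stands well beyond both of the others, as the values show.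

Compound 4 `COc1ccc(C=C(C(=O)c2cc(OC)c(OC)c(OC)c2)c2ccc(C)cc2)cc1O` has not yet been measured. It differs from compound 3 by the same exchange: hydroxy in place of fluoro on an aromatic carbon. The surroundings of the exchange read the same in both pairs, so it is the same change made on another core. The earlier step, a 1.2-fold lower number from compound 2 to compound 1 (0.09 log units; within the scatter), stayed within the scatter. For compound 4 only a small step is therefore expected as well: a 1.2-fold lower number from compound 3 to compound 4 (0.08 log units; within the scatter). Compound 4 is estimated at 470000 nM in this assay, with a plausible range from 150000 nM to 1500000 nM. Since the starting number is already very high, the assay could also report only a limit for compound 4.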

Compound 4, half-maximal inhibitory concentration: 32000 nM
Beside the measured number, compound 4's estimate is 15-fold (1.17 log units) above it; measured number below the stated range.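

The exchange of fluoro for hydroxy did not behave alike on the two cores in this assay: the same change on two cores in this assay, a 1.2-fold lower number (0.09 log units; within the scatter) from compound 2 to compound 1 and an 18-fold lower number (1.25 log units; beyond the scatter) from compound 3 to compound 4, 15-fold (1.16 log units) apart, beyond the scatter of two such steps

On one core the exchange brings an 18-fold lower number from compound 3 to compound 4 (1.25 log units; beyond the scatter), while on the other core the two compounds cannot be told apart, so the size of the step seen on one core could not be carried over to the other in this series. These two pairs do not show which part of the cores accounts for the gap, and they give no rule for what the same exchange would do on a third core.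

The compounds shown leave open how other groups would read at the same place on either core, for example an amine, a chloro group or a carboxylic acid. Also open, from the compounds shown here alone, is whether the gap between the two steps would appear in another read-out, since every number here comes from this assay.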